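This account rests on a few compounds, and the source may have more. Where it says the series, first, only, none or still open, it means among the compounds named here.

In a functional assay on CCRF-CEM cells (Homo sapiens) for inhibition, read by sulforhodamine B assay, with a stated time of 48 h (a lower number here means a stronger inhibitor of growth, a higher number a weaker inhibitor of growth), compound 1 `CC(C)c1ccc(Nc2ccc3c(OCCCN4CCN(C)CC4)cccc3n2)cc1` gives 3740 nM. Compound 2 `CN1CCN(CCCOc2cccc3nc(Nc4ccc(F)c(F)c4)ccc23)CC1` gives 2420 nM.

Within the data shown here, compound 2 thus carries the smaller of the two numbers, but the single measured step, a 1.5-fold lower number from compound 1 to compound 2 (0.19 log units; within the scatter), falls within the scatter, so the two compounds cannot be told apart on potency. Compound 3 `CN1CCN(CCCOc2cccc3nc(Nc4cc(Cl)cc(Cl)c4)ccc23)CC1` differs from compound 2 by 3,5-dichlorophenyl in place of 3,4-difluorophenyl on a nitrogen on an aromatic ring. Among the measured compounds shown here, no measured step swaps halogens on that ring; the one step that touched this group stayed within the scatter. The expected step is therefore a 1.0-fold higher number from compound 2 to compound 3 (0.01 log units; within the scatter), nothing beyond the scatter. Compound 3 is estimated at 2500 nM, in the range 900 nM to 7000 nM.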

Compound 3, concentration for 50% growth inhibition: 1780 nM
For compound 3 the middle estimate is 1.4-fold (0.15 log units) above the measured one, within the range that was stated.
By their numbers in this assay, from the lowest: compounds 3, 2 and 1 (each within the scatter of the next, the first and the last beyond it).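

In this assay, replacing 3,4-difluorophenyl with 3,5-dichlorophenyl on this nitrogen changes the number by no more than the scatter (a 1.4-fold lower number from compound 2 to compound 3 (0.13 log units; within the scatter)), so these two halogen-bearing rings cannot be told apart. Among these compounds, replacing 4-isopropylphenyl with 3,5-dichlorophenyl at the same place gives the first step here to pass the scatter, though only modestly (a 2.1-fold lower number from compound 1 to compound 3 (0.32 log units; beyond the scatter)). Nothing available explains either step.

From the compounds shown here alone, whether an amine or a carboxylic acid on this phenyl ring would move the number further remains open.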